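Methoxy in place of diethylamino on the shared core

The compounds below may be only part of what the source reports. "The series", "measured", "known", "first", "only" and "open" are said of these compounds alone.

Compound 1 `O=C(N/N=C/c1ccccc1O)c1cccc(S(=O)(=O)N2CCOCC2)c1`: 19600 nM
Compound 2 `CCN(CC)c1ccc(/C=N/NC(=O)c2cccc(S(=O)(=O)N3CCOCC3)c2)c(O)c1`: 920 nM

Among the compounds with values here, in a functional assay on EC9706 cells (Homo sapiens) for antiproliferative activity, read by MTT assay, with a stated time of 72 h (on this read-out lower numbers stand for stronger inhibition and higher numbers for weaker inhibition), compound 2 holds the lowest of the two numbers so far, with compound 1 as its only neighbour. Compound 3 `COc1ccc(/C=N/NC(=O)c2cccc(S(=O)(=O)N3CCOCC3)c2)c(O)c1` differs from compound 2 in one place: methoxy in place of diethylamino on an aromatic carbon. Within the data shown here, the only measured step at this spot, from hydrogen to diethylamino, was large: a 21-fold lower number from compound 1 to compound 2 (1.33 log units; beyond the scatter). Methoxy is neither of those two groups, so compound 3 is expected to land between the two measured numbers, a moderate rise, a 3.8-fold higher number from compound 2 to compound 3 (0.58 log units; beyond the scatter). Compound 3 is estimated at 3500 nM, with a range from 1000 nM to 12000 nM.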

Compound 3, half-maximal inhibitory concentration: 1090 nM
Estimate against measurement, compound 3: 3.2-fold (0.51 log units) above; the measured number falls inside the stated range.
By their numbers in this assay, from the lowest: compounds 2 and 3 (each within the scatter of the next); then compound 1.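

In this assay there is a 1.2-fold higher number from compound 2 to compound 3 (0.07 log units; within the scatter) and this lies within the scatter, so methoxy, with 2 heavy atoms, cannot be told apart from diethylamino, with 5 heavy atoms. The smaller group thus keeps the large gain over hydrogen, with an 18-fold lower number from compound 1 to compound 3 (1.25 log units; beyond the scatter) as its step. No measurement here offers an explanation for this match.

Still open, on these data alone, is how a plain amino group or a single fluorine atom would behave at this position on the shared core. A carboxylic acid there would show whether the gain extends to a very different kind of group.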